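This account rests on a few compounds, and the source may have more. Where it says the series, first, only, none or still open, it means among the compounds named here.

Compound 2 `CCC(=O)Nc1cc(C(=O)NC2CCC2)ccc1OC` sits at the edge of what an ADME assay on MDCK cells (Canis lupus familiaris) for cytotoxicity, read by cytopathic effect, with a stated time of 48 h (on this read-out higher numbers stand for lower toxicity in this test and lower numbers for higher toxicity in this test), can report: in this assay compound 2 gives > 724 uM, a limit of the assay rather than a number (the limit of > 724 uM in this assay, at which 1 of the 2 values shown sits). Compound 1 `CCC(=O)Nc1cc(C(=O)Nc2cccc(SC)c2)ccc1OC` gives 324 uM in this assay. Going by the values given here, the one measured step is an at least 2.2-fold higher number from compound 1 to compound 2 (0.34 log units; beyond the scatter). Compound 3 `CCC(=O)Nc1cc(C(=O)Nc2nccs2)ccc1OC` differs from compound 2 by 1,3-thiazol-2-yl in place of cyclobutyl on an amide-type nitrogen. That measured step concerned other groups, so for compound 3 only a step of uncertain direction is expected, an at least 1.4-fold lower number from compound 2 to compound 3 (0.16 log units; that floor lies within the scatter). Compound 3 is estimated at 500 uM, expected between 200 uM and 1000 uM.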

Compound 3, half-maximal toxic concentration: > 655 uM
Compound 3 ended at the assay's limit; the forecaster's own chance of this, stated with the estimate: 45%; at least 1.3-fold (0.11 log units) between middle value and limit.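

With 1,3-thiazol-2-yl on the amide-type nitrogen, this assay gives an at least 2.0-fold higher number from compound 1 to compound 3 (0.30 log units; that floor lies within the scatter), so an aromatic ring can stand here without a number as low as that of compound 1, although that floor does not clearly separate the two compounds. The step between compound 2 and compound 3 cannot be read. Compound 3, like compound 2, ends at a limit of the assay and not at a number: the limit of > 655 uM in this assay, at which 1 of the 3 values shown sits.

The compounds shown leave open how far compound 2 and compound 3 truly lie from each other. They also leave open whether a phenyl without the methylsulfanyl group, or a piperidine ring, on this nitrogen would give a number or a limit.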